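Triazolylsulfanyl Amide to Methylpiperazinyl Amide on Breast Cancer Cells

The source may hold more compounds than are shown below. What is called first, only, known or untested is meant among the compounds shown, and "the series" means these compounds.

Measured in a functional assay on MCF7 cells (Homo sapiens) for cytotoxicity, read by MTT assay, with a stated time of 24 h; on this read-out higher numbers stand for weaker inhibition and lower numbers for stronger inhibition:
compound 1, `Cn1c(-c2ccc(NC(=O)CCl)cc2)nc(-c2ccccc2)c1-c1ccccc1`, 42.6 ug/mL
compound 2, `Cc1ccc2oc(SCC(=O)Nc3ccc(-c4nc(-c5ccccc5)c(-c5ccccc5)n4C)cc3)nc2c1`, 22.4 ug/mL
compound 3, `Cn1cnnc1SCC(=O)Nc1ccc(-c2nc(-c3ccccc3)c(-c3ccccc3)n2C)cc1`, 3.2 ug/mL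

Compound 3 stands lowest of the three, with a 13-fold lower number from compound 1 to compound 3 (1.12 log units; beyond the scatter) and a 7.0-fold lower number from compound 2 to compound 3 (0.85 log units; beyond the scatter) both beyond the scatter. Compound 4, `CN1CCN(CC(=O)Nc2ccc(-c3nc(-c4ccccc4)c(-c4ccccc4)n3C)cc2)CC1`, differs from compound 3 by 4-methylpiperazin-1-yl in place of (4-methyl-4H-1,2,4-triazol-3-yl)sulfanyl on a saturated chain carbon bound to a carbonyl carbon. The two steps that bear on it are those that exchange the group on the same chain carbon, the steps from compound 1 and from compound 2 to compound 3; both lowered the number, one largely, one modestly. Among the compounds with values here, no measured compound carries the 4-methylpiperazin-1-yl group, so its direction rests only on compound 3 being the lowest of the set. Compound 4 is therefore expected to show a modestly higher number, a 4.7-fold higher number from compound 3 to compound 4 (0.67 log units; beyond the scatter), with an estimate of 15 ug/mL and a range from 4 ug/mL to 50 ug/mL.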

Compound 4, half-maximal inhibitory concentration: 76.5 ug/mL
The estimate for compound 4 lay 5.1-fold (0.71 log units) below the measured number; the whole stated range lies below it.
By their numbers in this assay, from the lowest: compound 3; then compounds 2, 1 and 4 (each within the scatter of the next, the first and the last beyond it).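

In this assay this chain carbon now shows a change upward as well as downward, with a 24-fold higher number from compound 3 to compound 4 (1.38 log units; beyond the scatter) between two groups of equal heavy-atom count, so that count alone does not set the number. Against the (5-methyl-1,3-benzoxazol-2-yl)sulfanyl group the change reads a 3.4-fold higher number from compound 2 to compound 4 (0.53 log units; beyond the scatter) while a 1.8-fold higher number from compound 1 to compound 4 (0.25 log units; within the scatter) leaves the 4-methylpiperazin-1-yl group level with chloro.

Going by these compounds, whether the low number of compound 3 goes with the sulfur or with the triazole ring stays open, as does what a morpholine or a dimethylamino group on the same carbon would give. Nothing given here explains these steps.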